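From compound 1 to compound 4: one ring exchanged

The compounds below may be only part of what the source reports. "The series", "measured", "known", "first", "only" and "open" are said of these compounds alone.

Measured so far in an ADME assay on microsomes from liver (Homo sapiens) for metabolic stability (a higher number here means faster removal of the compound, a lower number slower removal), and shown here:
compound 1 `CCn1cnc2c(-c3ccc(F)c(-c4cnn(C)c4)c3)cnnc21` gives 47 mL.min-1.g-1 as a number
compound 2 `CCn1cnc2c(-c3ccnc(Oc4cccc(S(=O)(=O)CC)c4)c3)cnnc21` gives < 8 mL.min-1.g-1 as a limit
compound 3 `CC(=O)N1CC(Oc2cc(-c3cnnc4c3ncn4C(C)C)ccc2F)C1` gives < 8 mL.min-1.g-1 as a limit

Compound 1 is the only one here with a true number. Compound 2 and compound 3 show only the limit of < 8 mL.min-1.g-1 in this assay, at which 2 of the 3 values shown sit, and no number.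

Compound 4 `CCn1cnc2c(-c3ccc(F)c(-c4ccnc(C)c4)c3)cnnc21` carries 2-methylpyridin-4-yl in place of the 1-methyl-1H-pyrazol-4-yl of compound 1, on an aromatic carbon ortho to a fluoro group 2-methylpyridin-4-yl in place of 1-methyl-1H-pyrazol-4-yl on an aromatic carbon and is otherwise the same.

Within the data shown here, no measured pair shows what such an exchange does in this assay and the data give no direction. Compound 1 at 47 mL.min-1.g-1 is therefore the only anchor for an expectation. An estimated step of a 1.0-fold lower number from compound 1 to compound 4 (0.02 log units; within the scatter) is expected to stay within the usual scatter. The estimate for compound 4 is 45 mL.min-1.g-1 with an expected range from 20 mL.min-1.g-1 to 90 mL.min-1.g-1 in this assay here.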

Compound 4, intrinsic clearance in microsomes: 157 mL.min-1.g-1
Compound 4: middle estimate off by 3.5-fold (0.54 log units), on the low side; measured number above the stated range.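

At this place, on an aromatic carbon ortho to a fluoro group, the choice of ring clearly matters in this assay: 2-methylpyridin-4-yl in place of 1-methyl-1H-pyrazol-4-yl gives a 3.3-fold higher number from compound 1 to compound 4 (0.52 log units; beyond the scatter). This first measured step at this place shows that one ring exchange alone, with the rest of the molecule unchanged, can speed removal. Nothing shown here gives a cause for this rise. Still open, going by these compounds, is whether the ring itself or its methyl group counts more. An unsubstituted phenyl ring, or a pyridine carrying an amine, would test how far this trend extends.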